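The source may hold more compounds than are shown below. What is called first, only, known or untested is meant among the compounds shown, and "the series" means these compounds.

Measured so far:
- compound 1 `COc1cc(OC)c(-c2coc3cc(OCC(=O)c4cccc(C(F)(F)F)c4)ccc3c2=O)cc1OC` gives > 10000 nM
- compound 2 `COc1cc(OC)c(-c2coc3cc(OCc4ccc(Cl)cc4)ccc3c2=O)cc1OC` gives 4400 nM

In a functional assay on HUVEC cells (Homo sapiens) for antiproliferative activity, read by MTT assay, with a stated time of 24 h (on this read-out lower numbers stand for stronger inhibition and higher numbers for weaker inhibition), compound 1 gives > 10000 nM, which is a limit of the assay rather than a measured number. Compound 2, by contrast, gives 4400 nM in this assay, a real number. Going by the values given here, the only measured step, an at least 2.2-fold lower number from compound 1 to compound 2 (0.35 log units; beyond the scatter), therefore reaches from a limit to a number.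

Compound 3 `COc1cc(OC)c(-c2coc3cc(OCc4ccccc4Br)ccc3c2=O)cc1OC` has not yet been measured. It differs from compound 1 as follows: 2-bromophenyl in place of (3-(trifluoromethyl)phenyl)carbonyl on a saturated chain carbon bound to an oxygen on an aromatic ring. Among the compounds with values here, this change resembles the one from compound 1 to compound 2 closely, since in both the same group leaves and a halogen-bearing phenyl enters at the same place. Within the data shown here, the one measured step that bears on it is an at least 2.2-fold lower number from compound 1 to compound 2 (0.35 log units; beyond the scatter), and a step in the same direction, of at least that size, is expected here. Because compound 1 sits at the limit of > 10000 nM in this assay, at which 1 of the 2 values shown sits, the true size of that step cannot be pinned down from the data.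

Compound 3 is therefore expected to give about 4500 nM in this assay, with a range of 1500 nM to 12000 nM. That estimate corresponds to an at least 2.2-fold lower number from compound 1 to compound 3 (0.34 log units; beyond the scatter), though a limit again cannot be excluded.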

Compound 3, half-maximal inhibitory concentration: > 10000 nM
Compound 3 was reported as a limit; the forecaster's own chance of this, stated with the estimate: 30%; at least 2.2-fold (0.34 log units) between middle value and limit.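

A halogen-bearing phenyl at this place does not by itself secure a measurable effect: in this assay, 2-bromophenyl in place of 4-chlorophenyl on a saturated chain carbon bound to an oxygen on an aromatic ring gives an at least 2.2-fold higher number from compound 2 to compound 3 (0.35 log units; beyond the scatter). This place therefore tells two closely related halogen-bearing phenyl groups apart, and among the three compounds only compound 2 carries a real number, while the other two stop at the same assay limit: the limit of > 10000 nM in this assay, at which 2 of the 3 values shown sit. The step between compound 1 and compound 3 cannot be read, as both values are limits.

Still open, from the compounds shown here alone, is whether the kind of halogen or where it sits on the phenyl ring matters, as 2-bromophenyl and 4-chlorophenyl differ in both, and a 4-bromophenyl or 2-chlorophenyl group at this place would separate the two. Also open, going by these compounds, is how an unsubstituted phenyl, an amine or a carboxylic acid would read on this same chain carbon.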